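Expected Step to a Phenylsulfonyl Compound

The source may report more compounds than this note shows. Statements on the series, on what has been measured and on what is new or still open speak of the compounds shown alone.

Within the data shown here, in a functional assay for inhibition, with Homo sapiens as the target (on this read-out lower numbers stand for tighter binding and higher numbers for weaker binding), compound 1 (`CC(C)(Sc1ccccc1)C1OCC(C/C=C\CCC(=O)O)C(c2cccnc2)O1`) gives 200 nM, and compound 2 (`Cc1ccc(SC(C)(C)C2OCC(C/C=C\CCC(=O)O)C(c3cccnc3)O2)c([N+](=O)[O-])c1`) gives 158 nM, so compound 2 stands within the scatter of the only other measured compound. Compound 3 (`CC(C)(C1OCC(C/C=C\CCC(=O)O)C(c2cccnc2)O1)S(=O)(=O)c1ccccc1`) is related to compound 2 as follows: a group of 9 heavy atoms (6 carbon, 2 oxygen, 1 sulfur; one six-membered aromatic ring of carbon only) in place of a group of 11 heavy atoms (7 carbon, 1 nitrogen, 2 oxygen, 1 sulfur; one six-membered aromatic ring of carbon only), on a saturated chain carbon bound to two saturated chain carbons and a saturated ring carbon. Among the measured compounds shown here, the one measured step, a 1.3-fold lower number from compound 1 to compound 2 (0.10 log units; within the scatter), replaces phenyl on a sulfur with 4-methyl-2-nitrophenyl and lies within the scatter. For the measured compounds named here, no measured compound carries phenylsulfonyl, so the evidence is thin and the range is wide. The expected change is no more than scatter, an estimated 1.6-fold higher number from compound 2 to compound 3 (0.20 log units; within the scatter). Compound 3 is estimated at 250 nM, within an expected range of 80 nM to 800 nM.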

Compound 3, dissociation constant: 3160 nM
The estimate for compound 3 lay 13-fold (1.10 log units) below the measured number; measured number outside the range, above it.
By their numbers in this assay, from the lowest: compounds 2 and 1 (each within the scatter of the next); then compound 3.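

On this saturated chain carbon, the state of the sulfur proved far more telling than the aromatic ring on it. In this assay phenylsulfonyl in place of phenylsulfanyl gives a 16-fold higher number from compound 1 to compound 3 (1.20 log units; beyond the scatter) and the comparison with the nitro-bearing compound gives a 20-fold higher number from compound 2 to compound 3 (1.30 log units; beyond the scatter), both large, so compound 3 stands apart from the two sulfanyl compounds. Nothing available explains this loss.

As far as these compounds go, whether a sulfinyl group or an ether oxygen in place of the sulfur would keep the lower numbers remains open. So does whether 4-methyl-2-nitrophenyl on the sulfonyl would show the same loss.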